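This account rests on a few compounds, and the source may have more. Where it says the series, first, only, none or still open, it means among the compounds named here.

Measured so far:
Compound 1, `CCOC(=O)c1c(CN(CC)Cc2ccccc2)nc2ccccc2c1-c1ccccc1`: 700 nM
Compound 2, `CCN(CC)C(=O)c1cc(-c2ccccc2)c2ccccc2c1`: 5 nM

In an assay on brain with Translocator protein (Rattus norvegicus) as the target (on this read-out higher numbers stand for weaker inhibition and lower numbers for stronger inhibition), compound 1 gives 700 nM, the highest of the two numbers shown, so it is the weaker binder of the pair. Compound 2 gives 5 nM in this assay, a far lower number, and the gap between the two is well beyond the scatter; compound 2 differs from compound 1 in more than one place, so this gap cannot be tied to any single change. The step followed here goes from compound 1 to compound 3, `CCCNC(=O)c1c(CN(CC)Cc2ccccc2)nc2ccccc2c1-c1ccccc1`, which has not yet been measured. The difference is propylamino in place of ethoxy on a carbonyl carbon. No comparable change between two measured compounds is available, so the size of this step can only be guessed. The expected step is a 2.8-fold lower number from compound 1 to compound 3 (0.45 log units; beyond the scatter) in this assay, toward a lower number, although a move the other way, or none beyond the scatter, would not be surprising. On this basis compound 3 is estimated at 250 nM in this assay, within a range from 40 nM to 1500 nM.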

Compound 3, half-maximal inhibitory concentration: 872 nM
Beside the measured number, compound 3's estimate is 3.5-fold (0.54 log units) below it; the range from low to high includes it.
By their numbers in this assay, from the lowest: compound 2; then compounds 1 and 3 (each within the scatter of the next).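

Replacing ethoxy with propylamino on a carbonyl carbon, which turns the ethoxycarbonyl group into a propylcarbamoyl group, gives a 1.2-fold higher number from compound 1 to compound 3 (0.10 log units; within the scatter) in this assay. Among the compounds shown here, this is the first direct reading of this position, and it shows that this exchange leaves the number indistinguishable from that of the starting compound, even though propylamino carries a hydrogen-bond donor that ethoxy lacks and lacks the hydrogen-bond acceptor that ethoxy carries. No supporting data bear on why the two numbers stay together, so the result stands as an observation without an explanation.

From the compounds shown here alone, this single pair covers only a small part of what could be placed at this position, so it remains open whether a carboxylic acid, a butylamino group or a longer chain on the same carbonyl carbon would shift the number beyond the scatter. For the compounds shown here, it is also open whether exchanging ethoxy for propylamino would give a similarly small step on a different core, since the only comparison available here uses the core of compound 1.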